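Two Spiro Compounds at the Assay Ceiling, and a Third

The source may hold more compounds than are shown below. What is called first, only, known or untested is meant among the compounds shown, and "the series" means these compounds.

Compound 1 `N#CC1=C(N)Oc2c(c3nc4ccccc4nc3c3ccccc23)C12C(=O)N(Cc1cnnn1-c1cc(Cl)ccc1Cl)c1ccccc12`: in an ADME assay on HUVEC cells (Homo sapiens) for antiproliferative activity, read by MTT assay, with a stated time of 48 h (on this read-out higher numbers stand for weaker inhibition and lower numbers for stronger inhibition), compound 1 gives > 50000 nM, a limit of the assay rather than a number.
Compound 2 `Cc1cccc(-n2nncc2CN2C(=O)C3(C(C#N)=C(N)Oc4c(N)cc5nc6ccccc6nc5c43)c3ccccc32)c1`: in this assay compound 2 gives > 50000 nM, again a limit of the assay.

Within the data shown here, both values known so far are limits, so compound 2 cannot be placed above or below compound 1; the two simply share (the limit of > 50000 nM in this assay, at which 2 of the 2 values shown sit). Neither compound shows measurable inhibition of the growth of these cells within the tested range.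

Compound 3 `N#CC1=C(N)Oc2c(N)cc3nc4ccccc4nc3c2C12C(=O)N(Cc1cnnn1-c1ccccc1Br)c1ccccc12` has not yet been measured. It differs from compound 2 in one place: 2-bromophenyl in place of 3-methylphenyl on an aromatic nitrogen. The shared core of the two compounds is otherwise untouched.

Among the measured compounds shown here, no measured pair differing in a single group exists here, so no step size can be read off. Given that compound 2 sits at > 50000 nM, the step of a number no higher from compound 2 to compound 3 (the limit leaves the size open) is expected to stay within the scatter. Compound 3 is therefore estimated at 50000 nM, with a range from 20000 nM to 120000 nM, most likely reported as a limit once more.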

Compound 3, half-maximal inhibitory concentration: 34200 nM
For compound 3 the middle estimate is 1.5-fold (0.16 log units) above the measured one; the range from low to high includes it.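

In this assay, among these compounds, compound 3 gives 34200 nM, the only value shown so far that is a number and not a limit of the assay, so the shared core can give a measurable reading with this group on the aromatic nitrogen of the five-membered ring. Putting 2-bromophenyl in place of 3-methylphenyl gives an at least 1.4-fold lower number from compound 2 to compound 3 (0.16 log units; that floor lies within the scatter), and this is a floor for the step, not its measured size. The true size stays unknown because one end of the step is a limit, as is the reading of compound 1: the limit of > 50000 nM in this assay, at which 2 of the 3 values shown sit.

The change moves the substituent on the phenyl ring and replaces methyl with bromine at once, so the compounds shown cannot separate the effect of the substituent's place from the effect of its identity. As far as these compounds go, how a plain phenyl group or a methoxyphenyl group on the same nitrogen would read in this assay also stays open, and such compounds would show whether any substituent on this ring is needed for a measurable value.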